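This account rests on a few compounds, and the source may have more. Where it says the series, first, only, none or still open, it means among the compounds named here.

Among the compounds with values here, compound 1 `CN(C[C@H]1Cc2c(cccc2N2CCC(N)CC2)CN1)[C@H]1CCCc2cccnc21` gives 33.4 nM in a functional assay on CCRF-CEM cells for antagonist activity at C-X-C chemokine receptor type 4 (Homo sapiens), read by calcium flux, with stated times of 25 min and 90 s (on this read-out lower numbers stand for stronger inhibition and higher numbers for weaker inhibition), the highest of the two numbers so far. Compound 2 `CN(C)[C@@H]1CCN(c2cccc3c2C[C@H](CN(C)[C@H]2CCCc4cccnc42)NC3)C1` gives 10.4 nM, and the step of a 3.2-fold lower number from compound 1 to compound 2 (0.51 log units; beyond the scatter) came with 3-(dimethylamino)pyrrolidin-1-yl in place of 4-aminopiperidin-1-yl on an aromatic carbon. Compound 3 `CN1C[C@@H]2CN(c3cccc4c3C[C@H](CN(C)[C@H]3CCCc5cccnc53)NC4)C[C@@H]2C1` differs from compound 1 by a group of 9 heavy atoms (7 carbon, 2 nitrogen; 2 five-membered non-aromatic rings with 1 hetero atom each) in place of a group of 7 heavy atoms (5 carbon, 2 nitrogen; one six-membered non-aromatic ring with 1 hetero atom), on an aromatic carbon. Within the data shown here, only that one step bears on the change; it too replaced the 4-aminopiperidin-1-yl with a group carrying 0 hydrogen-bond donors, so a modest lowering is expected, a 2.2-fold lower number from compound 1 to compound 3 (0.35 log units; beyond the scatter). Compound 3 is therefore estimated at 15 nM, within 6 nM to 40 nM.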

Compound 3, half-maximal inhibitory concentration: 9.56 nM
Compound 3: middle estimate off by 1.6-fold (0.20 log units), on the high side; low and high end bracket the measured number.
By their numbers in this assay, from the lowest: compounds 3 and 2 (each within the scatter of the next); then compound 1.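

Replacing 4-aminopiperidin-1-yl with the group of two five-membered rings gives a 3.5-fold lower number from compound 1 to compound 3 (0.54 log units; beyond the scatter) and shows that a second group with 0 hydrogen-bond donors also accompanies a lower number at this aromatic carbon. Exchanging 3-(dimethylamino)pyrrolidin-1-yl for that group gives a 1.1-fold lower number from compound 2 to compound 3 (0.04 log units; within the scatter) and so separates the two groups by no real difference, despite their different ring systems. No measurement shown here accounts for either result.

The compounds shown leave open how an open-chain group such as 2-(dimethylamino)ethyl or a carboxylic acid would fare on this aromatic carbon.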